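Spiro-cyclopropane lactam in place of methyl-lactam: solubility outlook

A few compounds are considered here, and "the series" means these few. Any claim that something is new, unique, unknown or untested is made for them only; others in the source may bear on it.

Measured compounds:
compound 1 `Cn1cc(-c2cnc(NCc3c(F)ccc4c3CCO4)c3cn[nH]c(=O)c23)cn1` gives 1000 nM
compound 2 `C[C@@H]1CC(=O)N(c2cnc(NCc3c(F)ccc4c3CCO4)n3cnnc23)C1` gives 130000 nM

Of the compounds shown here, two have been measured in a physicochemical assay for solubility, read by LC-MS, in phosphate buffer, with a stated time of 24 h, at pH 7.4; on this read-out lower numbers stand for lower solubility and higher numbers for higher solubility. In this assay compound 1 gives 1000 nM. In this assay compound 2 gives 130000 nM, the highest of the two numbers; its nearest neighbour is compound 1, and the gap between them lies beyond the scatter. Going by the values given here, no pair of measured compounds differs in a single place, so no measured step is available to guide the next change.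

Compound 3 `O=C1CC2(CC2)CN1c1cnc(NCc2c(F)ccc3c2CCO3)n2cnnc12` has not yet been measured in this assay. It differs from compound 2 in one place: a group of 8 heavy atoms (6 carbon, 1 nitrogen, 1 oxygen; one three-membered non-aromatic ring of carbon only, one five-membered non-aromatic ring with 1 hetero atom) in place of a group of 7 heavy atoms (5 carbon, 1 nitrogen, 1 oxygen; one five-membered non-aromatic ring with 1 hetero atom), on an aromatic carbon. The group that leaves carries 1 defined stereocentre; the group that enters has none and adds a three-membered non-aromatic ring of carbon only. Both groups keep 0 hydrogen-bond donors and 1 hydrogen-bond acceptor.

Among the compounds with values here, with no measured step of this kind to draw on, the expected step from compound 2 to compound 3 is a 1.4-fold lower number from compound 2 to compound 3 (0.16 log units; within the scatter), small and not clearly beyond the scatter. Compound 3 is therefore estimated at 90000 nM in this assay, within a range from 30000 nM to 250000 nM.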

Compound 3, solubility: 130000 nM
For compound 3 the middle estimate is 1.4-fold (0.16 log units) below the measured one, within the range that was stated.
By their numbers in this assay, from the lowest: compound 1; then compounds 2 and 3 (each within the scatter of the next).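

In this assay, replacing the 4-methyl-2-oxopyrrolidin-1-yl group with the lactam that carries a three-membered ring of carbon only gives no change at the digits printed from compound 2 to compound 3 (within the scatter) on this aromatic carbon, which sits on the six-membered aromatic ring. Going by these compounds alone, this is the first single-place comparison, and it shows that this position can lose the defined stereocentre and gain a three-membered ring of carbon only while the two numbers stay within the scatter of each other. No measurement shown here accounts for this reading.

The compounds leave open whether this position keeps its reading only with a lactam, since only two closely related lactams are shown there, and a morpholine, a primary amine or a carboxylic acid on the same aromatic carbon could read quite differently. They also leave open how the opposite stereoisomer of the 4-methyl-2-oxopyrrolidin-1-yl group, or a four-membered carbon ring in place of the three-membered one, would read in this assay.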